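The compounds below may be only part of what the source reports. "The series", "measured", "known", "first", "only" and "open" are said of these compounds alone.

In an ADME assay on CHO cells (Cricetulus griseus) for cytotoxicity, read by MTT assay (on this read-out lower numbers stand for higher toxicity in this test and higher numbers for lower toxicity in this test), compound 1 (`Fc1ccc(Nc2cc3[nH]c(Nc4ccc(N5CCN(C6CC6)CC5)cn4)nc3cn2)cc1C(F)(F)F`) gives 23000 nM and compound 2 (`Fc1ccc(Nc2cc3[nH]c(Nc4ccc(N5CCN(CC6CC6)CC5)cn4)nc3cn2)cc1C(F)(F)F`) gives 41000 nM so the two stand within the scatter of each other. Compound 3 (`FC(F)(F)c1cccc(Nc2cc3[nH]c(Nc4ccc(N5CCN(CC6CC6)CC5)cn4)nc3cn2)c1`) has hydrogen in place of fluoro on an aromatic carbon. For the measured compounds named here, the only measured step is a 1.8-fold higher number from compound 1 to compound 2 (0.25 log units; within the scatter) at another place in the molecule, so no measured step covers this change, and none beyond the scatter is expected in this assay for compound 3. The estimated 1.2-fold lower number from compound 2 to compound 3 (0.07 log units; within the scatter) stays within the scatter. Compound 3 is expected at 35000 nM with an estimated range from 16000 nM to 75000 nM on this read-out.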

Compound 3, half-maximal cytotoxic concentration: 1700 nM
Beside the measured number, compound 3's estimate is 21-fold (1.31 log units) above it; the whole stated range lies above it.
By their numbers in this assay, from the lowest: compound 3; then compounds 1 and 2 (each within the scatter of the next).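

In this assay, going from 4-fluoro-3-(trifluoromethyl)phenyl to 3-(trifluoromethyl)phenyl gives a 24-fold lower number from compound 2 to compound 3 (1.38 log units; beyond the scatter), so the read-out responds strongly to this one aromatic carbon, ortho to the trifluoromethyl group. The earlier change, on the ring amine nitrogen, stayed within the scatter and gave no sign of such a sensitive place. Nothing measured here explains the size of this step.

Going by these compounds, whether chloro, methoxy or a nitrile at this carbon would read closer to compound 2 or to compound 3 remains open. So does whether the step would recur with cyclopropyl in place of cyclopropylmethyl.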